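Chloro to Tert-Butoxycarbonyl on a Weak Inhibitor

A few compounds are considered here, and "the series" means these few. Any claim that something is new, unique, unknown or untested is made for them only; others in the source may bear on it.

Of the compounds shown here, three have been measured in an assay on isolated protein for inhibition of long-chain fatty acid transport protein 1 (Mus musculus); on this read-out higher numbers stand for weaker inhibition and lower numbers for stronger inhibition. Compound 1 `CCc1ccc2oc(CSc3nnc(CNc4ccccc4)n3CC)nc2c1` gives 1800 nM. Compound 2 `CCC(=O)c1ccc2oc(CS(=O)(=O)c3nnc(CNc4ccccc4)n3CC)nc2c1` gives 11900 nM in this assay. Compound 3 `CCn1c(CNc2ccccc2)nnc1SCC(=O)Nc1ccc(Cl)cc1` gives > 10000 nM in this assay, and this is a limit of the assay rather than a number. Compound 3 thus sits at the limit of > 10000 nM in this assay, at which 1 of the 3 values shown sits, so its inhibition is known only to be weaker than the edge of what the assay reports.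

Compound 4 `CCn1c(CNc2ccccc2)nnc1SCC(=O)Nc1ccc(C(=O)OC(C)(C)C)cc1` has not yet been measured. It differs from compound 3 by tert-butoxycarbonyl in place of chloro on an aromatic carbon. Among the compounds with values here, no step between two measured compounds exists for this kind of change, and compound 3 itself stands at the limit of > 10000 nM in this assay, at which 1 of the 3 values shown sits, so no movement beyond the usual scatter is expected in this assay, in either direction. Compound 4 is expected to give 15000 nM, with a range from 5000 nM to 50000 nM. The expected step that the limit leaves unreadable from compound 3 to compound 4 is therefore judged to be small.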

Compound 4, half-maximal inhibitory concentration: > 10000 nM
Compound 4 was reported as a limit; the forecaster's own chance of this, stated with the estimate: 60%; the middle value does not contradict the limit.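

In this assay, within the data shown here, compound 3 and compound 4 both stand at a limit rather than a number, so no step between them can be read. On these data alone, whether tert-butoxycarbonyl in place of chloro changes inhibition at all remains open, as does how far either compound lies beyond that limit.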